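This account rests on a few compounds, and the source may have more. Where it says the series, first, only, none or still open, it means among the compounds named here.

Of the compounds shown here, two have been measured in a functional assay on DLD-1 cells (Homo sapiens); a higher number here means a weaker inhibitor, a lower number a stronger inhibitor. Compound 1 `CC(C)C/N=C(\S)N1CCN(c2ccc(N(Cc3c[nH]cn3)S(=O)(=O)c3ccccc3)cc2)CC1` gives 800 nM. Compound 2 `N#Cc1ccc(Cn2cncc2CN(C(=O)c2ccccc2)c2ccc(N3CCN(C(=O)c4ccc(Cl)s4)CC3)cc2)cc1` gives 3 nM, the lowest of the two numbers, and its nearest neighbour is compound 1 with a far higher number, a gap well beyond the scatter. Compound 3 `N#Cc1ccc(Cn2cncc2CN(c2ccc(N3CCN(C(=O)c4ccc(Cl)s4)CC3)cc2)S(=O)(=O)c2ccccc2)cc1` is derived from compound 2 by one change, phenylsulfonyl in place of benzoyl on a nitrogen on an aromatic ring. Among the compounds with values here, no single-change step between measured compounds is available. Compound 1 also carries the phenylsulfonyl group on that nitrogen, yet it differs from compound 2 in more than one place, so its value gives only a loose hint. The step from compound 2 to compound 3 is expected to raise the number, perhaps a 10-fold higher number from compound 2 to compound 3 (1.00 log units; beyond the scatter). Compound 3 is therefore estimated at 30 nM, within a range from 6 nM to 150 nM.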

Compound 3, half-maximal inhibitory concentration: 200 nM
Compound 3: the middle estimate sits 6.7-fold (0.82 log units) below what was measured; the measured number lies above the stated range.
By their numbers in this assay, from the lowest: compound 2; then compound 3; then compound 1.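

This position, on a nitrogen on an aromatic ring, proves sensitive in this assay and putting phenylsulfonyl in place of benzoyl, with the rest of the molecule unchanged, gives a 67-fold higher number from compound 2 to compound 3 (1.82 log units; beyond the scatter) as a large step. Compound 1 and compound 2 differ in more than one place, so their gap could not be tied to this nitrogen, whereas this pair shows that benzoyl gives by far the lower number here, although both groups carry one six-membered aromatic ring of carbon only. Nothing at hand accounts for the size of this step.

Within the data shown here, whether the step holds on another core stays open, as this single pair is the only comparison of the two groups. Also open, as far as these compounds go, is how a smaller group such as acetyl, or a benzyl group on this nitrogen, would compare with benzoyl.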